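The compounds below may be only part of what the source reports. "The series", "measured", "known", "first", "only" and "open" are said of these compounds alone.

Measured compounds:
compound 1 `CCN(CC)C(=O)[C@@H]1CCCN(S(=O)(=O)c2ccc(S(=O)(=O)N(CC)CC)cc2)C1` — 700 nM
compound 2 `CCN(CC)S(=O)(=O)c1ccc(S(=O)(=O)N2CCC[C@@H](C(=O)NC3COC3)C2)cc1` — 900 nM

Within the data shown here, compound 2 gives the higher of the two numbers in a functional assay on MIA PaCa-2 cells (Homo sapiens) for inhibition, read by MTT assay, with a stated time of 3 days (a lower number here means a stronger inhibitor, a higher number a weaker inhibitor), but its only neighbour, compound 1, lies within the scatter of it: a 1.3-fold higher number from compound 1 to compound 2 (0.11 log units; within the scatter). The two values therefore cannot be ranked.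

Compound 3 `CCN(CC)S(=O)(=O)c1ccc(S(=O)(=O)N2CCC[C@@H](C(=O)NC3CN(C(=O)OC(C)(C)C)C3)C2)cc1` differs from compound 2 in one place: 1-(tert-butoxycarbonyl)azetidin-3-yl in place of oxetan-3-yl on an amide-type nitrogen. Among the measured compounds shown here, the sole measured step, from compound 1 to compound 2, also changed the group on this amide-type nitrogen and stayed within the scatter, so it is the only step that bears on the change, and it offers no evidence that the group on this nitrogen moves the number.

For compound 3 the expected value in this assay is 1000 nM, with a range of 400 nM to 2500 nM. The step this estimate implies, a 1.1-fold higher number from compound 2 to compound 3 (0.05 log units; within the scatter), is expected to stay within the scatter.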

Compound 3, half-maximal inhibitory concentration: 100 nM
Estimate against measurement, compound 3: 10-fold (1.00 log units) above, outside the stated range (below it).
By their numbers in this assay, from the lowest: compound 3; then compounds 1 and 2 (each within the scatter of the next).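

In this assay the group on the amide-type nitrogen proves able to move the number: 1-(tert-butoxycarbonyl)azetidin-3-yl in place of oxetan-3-yl gives a 9.0-fold lower number from compound 2 to compound 3 (0.95 log units; beyond the scatter), whereas the earlier change at this place stayed within the scatter. Read against the diethylamino group, (1-(tert-butoxycarbonyl)azetidin-3-yl)amino gives a 7.0-fold lower number from compound 1 to compound 3 (0.85 log units; beyond the scatter), so compound 3 stands apart from both earlier compounds, which themselves remain unranked. Nothing measured on these compounds accounts for this step.

The compounds shown leave open whether the step belongs to the tert-butoxycarbonyl group or to the azetidine ring, as the two enter together in one change. A free azetidin-3-yl amine or a 1-acetylazetidin-3-yl group on the same nitrogen would separate the two.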